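Working notes: from compound 3 to compound 4

A few compounds are considered here, and "the series" means these few. Any claim that something is new, unique, unknown or untested is made for them only; others in the source may bear on it.

- compound 1 (`Nc1nc(N)c2cc(CSC(=S)N3CCN(C4CCCCC4)CC3)ccc2n1`) gives (4050 nM)
- compound 2 (`Nc1nc(N)c2cc(CSC(=S)N3CCN(c4ccc(Cl)cc4)CC3)ccc2n1`) gives (7480 nM)
- compound 3 (`Nc1nc(N)c2cc(CSC(=S)N3CCN(c4ccccc4F)CC3)ccc2n1`) gives (5420 nM)

In a functional assay on HT-29 cells (Homo sapiens) for antiproliferative activity, read by MTT assay, with a stated time of 72 h (on this read-out lower numbers stand for stronger inhibition and higher numbers for weaker inhibition), compound 3 (5420 nM) cannot be separated from the other two measured compounds, as both of its steps stay within the scatter: (a 1.3-fold higher number from compound 1 to compound 3 (0.13 log units; within the scatter)) and (a 1.4-fold lower number from compound 2 to compound 3 (0.14 log units; within the scatter)).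

Compound 4 (`CC(=O)c1ccc(N2CCN(C(=S)SCc3ccc4nc(N)nc(N)c4c3)CC2)cc1`) has not been measured. It carries 4-acetylphenyl in place of 2-fluorophenyl on an amine nitrogen in a ring.

The relevant evidence comes from the measured exchanges at this same place. The exchange between the two substituted phenyl groups gave (a 1.4-fold lower number from compound 2 to compound 3 (0.14 log units; within the scatter)). Replacing cyclohexyl gave (a 1.8-fold higher number from compound 1 to compound 2 (0.27 log units; within the scatter)) and (a 1.3-fold higher number from compound 1 to compound 3 (0.13 log units; within the scatter)). None of these steps goes beyond the scatter, so this place has so far shown no measurable response in this assay. Going by the values given here, no measured compound carries 4-acetylphenyl, however, and three compounds make a thin basis for any expectation.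

No step beyond the scatter is expected, and no direction is favoured. The expected step is (a 1.0-fold higher number from compound 3 to compound 4 (0.01 log units; within the scatter)). Compound 4 is estimated at (5500 nM), with an expected range from (2600 nM) to (11500 nM).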

Compound 4, half-maximal inhibitory concentration: 2280 nM
For compound 4 the middle estimate is 2.4-fold (0.38 log units) above the measured one, and the stated range ends above it.
By their numbers in this assay, from the lowest: compounds 4, 1, 3 and 2 (each within the scatter of the next, the first and the last beyond it).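

In this assay, going by these compounds alone, this place, on an amine nitrogen in a ring, responds beyond the scatter for the first time, and both steps are modest (a 2.4-fold lower number from compound 3 to compound 4 (0.38 log units; beyond the scatter)) and (a 3.3-fold lower number from compound 2 to compound 4 (0.52 log units; beyond the scatter)). The second of these is the cleanest reading of the change, since acetyl replaces chloro on an otherwise unchanged phenyl group, while cyclohexyl remains within the scatter of 4-acetylphenyl (a 1.8-fold lower number from compound 1 to compound 4 (0.25 log units; within the scatter)), so compound 1 goes against any claim that compound 4 stands apart from all the others. The response therefore holds only among the substituted phenyl groups, and no measurement at hand accounts for it.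

The compounds shown leave open whether the lower number follows the carbonyl specifically or would also appear with another group in place of acetyl, such as a nitrile, a carboxylic acid or an amine. Also open, from the compounds shown here alone, is whether acetyl would give a similar step on a saturated ring, as in 4-acetylcyclohexyl compared directly with the cyclohexyl group of compound 1.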